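Fluoro to hydrogen: the step from compound 3 to compound 4

A few compounds are considered here, and "the series" means these few. Any claim that something is new, unique, unknown or untested is made for them only; others in the source may bear on it.

Measured so far in an in vitro functional assay on cells for agonist activity at Bombesin receptor subtype-3 (Mus musculus), read by luminescence and calcium flux; on this read-out higher numbers stand for an effect only at larger amounts of compound and lower numbers for an effect already at smaller amounts:
compound 1 `O=C(O)c1ccccc1-c1ccc(CCc2ncc(CCC3CCCCC3)[nH]2)cc1` gives 33 nM
compound 2 `N#Cc1ccc(Cc2cnc(CCc3ccc(-c4ccccc4C(=O)O)cc3)[nH]2)cc1` gives 723 nM
compound 3 `O=C(O)c1ccccc1-c1ccc(CCc2ncc(Cc3cccc(F)c3)[nH]2)cc1` gives 7.9 nM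

Compound 3 has the lowest number of the three in this assay; the steps of a 4.2-fold lower number from compound 1 to compound 3 (0.62 log units; beyond the scatter) and a 92-fold lower number from compound 2 to compound 3 (1.96 log units; beyond the scatter) set it apart from both others, each beyond the scatter. Compound 4 `O=C(O)c1ccccc1-c1ccc(CCc2ncc(Cc3ccccc3)[nH]2)cc1` differs from compound 3 by hydrogen in place of fluoro on an aromatic carbon. Among the measured compounds shown here, no measured step removes a single fluoro. The steps of a 22-fold higher number from compound 1 to compound 2 (1.34 log units; beyond the scatter), a 4.2-fold lower number from compound 1 to compound 3 (0.62 log units; beyond the scatter) and a 92-fold lower number from compound 2 to compound 3 (1.96 log units; beyond the scatter) all exchange the whole group on the saturated chain carbon bound to an aromatic carbon, and they show that this part of the molecule can move the number a great deal; the present change is much smaller. The expected step is a 1.8-fold higher number from compound 3 to compound 4 (0.25 log units; within the scatter), probably within the scatter or a modest rise. For compound 4 the estimate in this assay is 14 nM, with a range from 5 nM to 40 nM.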

Compound 4, half-maximal effective concentration: 11 nM
Compound 4: middle estimate off by 1.3-fold (0.10 log units), on the high side; the range from low to high includes it.
By their numbers in this assay, from the lowest: compounds 3 and 4 (each within the scatter of the next); then compound 1; then compound 2.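

Removing the fluoro gives a 1.4-fold higher number from compound 3 to compound 4 (0.14 log units; within the scatter), so the 3-fluorobenzyl and benzyl groups cannot be told apart here, and the fluoro is not required for a low number. The unsubstituted phenyl also gives a 66-fold lower number from compound 2 to compound 4 (1.82 log units; beyond the scatter) on exchanging cyano for hydrogen and a 3.0-fold lower number from compound 1 to compound 4 (0.48 log units; beyond the scatter) against cyclohexylmethyl, which ties the large rise to cyano rather than to the benzyl group itself. No evidence on the origin of these steps is available.

As far as these compounds go, whether methoxy or an amine on this ring would behave like fluoro or like cyano stays open. So does the effect of a longer chain carrying this ring.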